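Hydroxy on compound 3: expected shift in antiproliferative potency

The compounds below may be only part of what the source reports. "The series", "measured", "known", "first", "only" and "open" are said of these compounds alone.

Among the measured compounds shown here, in a functional assay on K562 cells (Homo sapiens) for antiproliferative activity, read by MTT assay, with a stated time of 5 days (on this read-out higher numbers stand for weaker inhibition and lower numbers for stronger inhibition), compound 3 `COc1ccc(C=C(C(=O)c2cc(OC)c(OC)c(OC)c2)c2ccc(C)cc2)cc1` gives 760000 nM, the second highest of the three numbers so far. Compound 1 `COc1ccc(C=C(C(=O)c2cc(OC)c(OC)c(OC)c2)c2ccc(C)cc2)cc1[N+](=O)[O-]` stands higher at 2430000 nM, and compound 2 `COc1ccc(C(=Cc2ccc(OC)c(O)c2)C(=O)c2cc(OC)c(OC)c(OC)c2)cc1`, the lowest of the three, gives 12000 nM.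

The next structure is compound 4 `COc1ccc(C=C(C(=O)c2cc(OC)c(OC)c(OC)c2)c2ccc(C)cc2)cc1O`, with this change from compound 3: hydroxy in place of hydrogen on an aromatic carbon. This is hydroxy in place of hydrogen on an aromatic carbon, taking 4-methoxyphenyl to 3-hydroxy-4-methoxyphenyl.

For the measured compounds named here, only one measured step involves that carbon: a 3.2-fold lower number from compound 1 to compound 3 (0.50 log units; beyond the scatter), with hydrogen in place of nitro. Going by the values given here, it is modest and beyond the scatter, but it concerns nitro rather than hydroxy, so it shows only that the number moves with the group at this carbon. The better guide is compound 2, which already carries 3-hydroxy-4-methoxyphenyl and gives 12000 nM in this assay. The rest of its structure is not identical to that of compound 3, so that value is not carried over whole.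

A large expected move toward stronger inhibition is a 19-fold lower number from compound 3 to compound 4 (1.28 log units; beyond the scatter). For compound 4 the estimated value is 40000 nM, with an expected range of 8000 nM to 250000 nM.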

Compound 4, half-maximal inhibitory concentration: 32000 nM
Compound 4: the middle estimate sits 1.3-fold (0.10 log units) above what was measured, within the range that was stated.
By their numbers in this assay, from the lowest: compound 2; then compound 4; then compound 3; then compound 1.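

In this assay the hydroxy group is now read directly against hydrogen at the carbon ortho to a methoxy group, with a 24-fold lower number from compound 3 to compound 4 (1.38 log units; beyond the scatter) as a large step beyond the scatter, and against nitro at the same carbon, with a 76-fold lower number from compound 1 to compound 4 (1.88 log units; beyond the scatter) as a larger step, so that the three groups at this carbon run hydroxy, hydrogen, nitro from the lowest number to the highest. Elsewhere in the structure, methyl in place of methoxy gives a 2.7-fold higher number from compound 2 to compound 4 (0.43 log units; beyond the scatter) as a modest step, still beyond the scatter, which makes it much smaller than the step for hydroxy in place of hydrogen and shows that 3-hydroxy-4-methoxyphenyl keeps most of its low number with either group at that other carbon. No measurement at hand accounts for any of these steps.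

Still open, from the compounds shown here alone, is whether an amine or a longer chain on the oxygen at this carbon would stay with hydroxy at the low end of the numbers or fall back toward hydrogen. Among the compounds shown here, also open is how far the size of the hydroxy step depends on the methyl group elsewhere in the structure, as a single pair gives the only reading of hydrogen to hydroxy here.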